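Adding a Hydroxyl to the Benzyl Group of Compound 1

This account rests on a few compounds, and the source may have more. Where it says the series, first, only, none or still open, it means among the compounds named here.

Compound 1 `Cc1ccc(CNc2ncnc3c2ncn3[C@@H]2O[C@H](CO)[C@@H](O)[C@H]2O)cc1` carries a 4-methylbenzyl group on a nitrogen of the shared core. In a functional assay on K562 cells (Homo sapiens) for antiproliferative activity, with a stated time of 72 h (on this read-out lower numbers stand for stronger inhibition and higher numbers for weaker inhibition), compound 1 gives only a limit, > 166000 nM, so its true strength is not known. Its value is the limit of > 166000 nM in this assay, at which 1 of the 2 values shown sits.

Compound 2 `COc1cccc(CNc2ncnc3c2ncn3[C@@H]2O[C@H](CO)[C@@H](O)[C@H]2O)c1O` differs from compound 1 in one place, and in this assay compound 2 gives 27900 nM. Among the measured compounds shown here, the step between them, an at least 5.9-fold lower number from compound 1 to compound 2 (0.77 log units; beyond the scatter), is the only measured step that bears on the compound considered next.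

Compound 3 `Cc1cccc(CNc2ncnc3c2ncn3[C@@H]2O[C@H](CO)[C@@H](O)[C@H]2O)c1O` is still to be measured. Its change from compound 1 is 2-hydroxy-3-methylphenyl in place of 4-methylphenyl on a saturated chain carbon bound to a nitrogen on an aromatic ring. For the measured compounds named here, the entering group closely resembles the one in compound 2: both carry a hydroxyl, and they differ only in a methyl against a methoxy. A drop in the number of similar size to an at least 5.9-fold lower number from compound 1 to compound 2 (0.77 log units; beyond the scatter) is therefore expected, though its true extent is uncertain because compound 1 sits at the limit of > 166000 nM in this assay, at which 1 of the 2 values shown sits.

Compound 3 is expected to give about 30000 nM in this assay, within a range from 9000 nM to 110000 nM. This estimate corresponds to an expected step of an at least 5.5-fold lower number from compound 1 to compound 3 (0.74 log units; beyond the scatter).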

Compound 3, half-maximal inhibitory concentration: 18000 nM
For compound 3 the middle estimate is 1.7-fold (0.22 log units) above the measured one; the range from low to high includes it.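

In this assay, 2-hydroxy-3-methylphenyl in place of 4-methylphenyl gives an at least 9.2-fold lower number from compound 1 to compound 3 (0.96 log units; beyond the scatter), so the 2-hydroxy-3-methoxyphenyl group of compound 2 is no longer the only hydroxyl-bearing group shown to give a lower number at this place. Methyl in place of methoxy on the aromatic carbon gives a 1.6-fold lower number from compound 2 to compound 3 (0.19 log units; within the scatter), so this read-out does not tell these two groups apart, and either one, carried with the hydroxyl, gives a similar result. Compound 1 has only a limit and not a true number, so the full size of each step that starts from it cannot be fixed: the limit of > 166000 nM in this assay, at which 1 of the 3 values shown sits.

On these data alone, the hydroxyl and its methyl or methoxy neighbour always enter together in these compounds, so what the hydroxyl contributes by itself remains open, as does whether an amine or a fluorine in its place would give a similar number. As far as these compounds go, it is also open whether a chlorine or a longer chain in place of the methyl would lower the number further, or would instead lose the gain seen with compound 3.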